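Acyloxy and aryloxy naphthoquinones: cytotoxicity notes

The compounds below may be only part of what the source reports. "The series", "measured", "known", "first", "only" and "open" are said of these compounds alone.

In a functional assay on KB cells (Homo sapiens) for cytotoxicity (on this read-out lower numbers stand for stronger inhibition and higher numbers for weaker inhibition), compound 1 `CC(=O)OC1=CC(=O)c2ccccc2C1=O` gives 38800 nM and stands highest of the three numbers recorded. Compound 2 `O=C1C=CC(=O)c2c(Oc3ccco3)cccc21` gives 13400 nM in this assay and compound 3 `O=C1C=CC(=O)c2c(Oc3cccs3)cccc21` gives 6230 nM in this assay, the step being a 2.2-fold lower number from compound 2 to compound 3 (0.33 log units; beyond the scatter). Among the measured compounds shown here, that is the only step between measured compounds, and it concerns an aryl group on an oxygen on an aromatic ring of the shared core, not the ester carbonyl.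

Compound 4 `C/C=C/C(=O)OC1=CC(=O)c2ccccc2C1=O` differs from compound 1 by prop-1-en-1-yl in place of methyl on a carbonyl carbon. For the measured compounds named here, no measured step touches the acyl side of the ester, so the expectation rests on the absence of a precedent rather than on one. A prop-1-en-1-yl in place of methyl on a carbonyl carbon is expected to leave the number close to that of compound 1, with a 1.3-fold lower number from compound 1 to compound 4 (0.11 log units; within the scatter) expected to stay within the scatter. Compound 4 is therefore estimated at 30000 nM in this assay, with a range from 12000 nM to 80000 nM.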

Compound 4, half-maximal inhibitory concentration: 64200 nM
Estimate against measurement, compound 4: 2.1-fold (0.33 log units) below; low and high end bracket the measured number.
By their numbers in this assay, from the lowest: compound 3; then compound 2; then compounds 1 and 4 (each within the scatter of the next).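

Among the compounds shown here, the step of a 1.7-fold higher number from compound 1 to compound 4 (0.22 log units; within the scatter) in this assay is the first reading of the acyl side of the ester, and it lies within the scatter. On this carbonyl carbon, prop-1-en-1-yl, with its double bond outside aromatic rings, cannot be told apart from methyl, so compounds 1 and 4 are best read as one level. No measurement at hand offers a reason for this result.

Going by these compounds, whether the same holds for a longer chain such as butyl, for a phenyl ring or for an amine on that carbonyl carbon stays open. Also open, on these data alone, is whether the double bond plays any part, which a saturated propyl group at the same place would show.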